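The source may report more compounds than this note shows. Statements on the series, on what has been measured and on what is new or still open speak of the compounds shown alone.

Compound 1 `CSc1cnc2ccccc2c1[Se]CC#CCO` was tested in a functional assay on SW707 cells (Homo sapiens) for antiproliferative activity, with a stated time of 72 h (a higher number here means a weaker inhibitor, a lower number a stronger inhibitor), where compound 1 gives 3.4 ug/mL. Its companion compound 2 `CSc1cnc2ccccc2c1[Se]CC#CCOC(=O)c1ccccc1` gives 3.6 ug/mL in this assay, and the change from hydrogen to benzoyl on the oxygen brings a 1.1-fold higher number from compound 1 to compound 2 (0.02 log units; within the scatter), so the two numbers are equivalent within the scatter and compound 1 stands level with compound 2 among the measured pair.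

The step to compound 3 `CSc1cnc2ccccc2c1SCC#CCCl` is different in kind: a group of 6 heavy atoms (4 carbon, 1 sulfur, 1 chlorine; no ring) in place of a group of 6 heavy atoms (4 carbon, 1 oxygen, 1 selenium; no ring), on an aromatic carbon. Among the measured compounds shown here, the one measured step, from compound 1 to compound 2, touches only the oxygen end of the chain and leaves the selenium in place, so it bears on this change only loosely. Nothing measured speaks to sulfur in place of selenium or chlorine in place of the hydroxyl. The step of a 1.0-fold higher number from compound 1 to compound 3 (0.01 log units; within the scatter) is therefore expected to be small, with a wide margin. For compound 3 the estimate in this assay is 3.5 ug/mL, ranging from 1.5 ug/mL to 9 ug/mL.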

Compound 3, concentration for 50% inhibition: 3.7 ug/mL
Compound 3: the middle estimate sits 1.1-fold (0.02 log units) below what was measured; the measured number falls inside the stated range.
By their numbers in this assay, from the lowest: compounds 1, 2 and 3 (each within the scatter of the next).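

In this assay, replacing the whole chain on this aromatic carbon, with sulfur in place of selenium and chlorine in place of the hydroxyl, gives a 1.1-fold higher number from compound 1 to compound 3 (0.04 log units; within the scatter), so the two compounds are equivalent within the scatter. The earlier pair varied only the oxygen end of the chain and kept the selenium, whereas this step shows that a chain with sulfur, chlorine and 0 hydrogen-bond donors at this position, opposite the ring nitrogen, still gives a number level with that of the hydroxyl chain carrying selenium. Nothing at hand offers an explanation for this level result.

Sulfur and chlorine entered together, so what each exchange does alone stays open. Also open, from the compounds shown here alone, is whether an amine, a carboxylic acid or a longer chain in place of the chlorine would stay level with compound 3 in this assay.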